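This account rests on a few compounds, and the source may have more. Where it says the series, first, only, none or still open, it means among the compounds named here.

Measured in a functional assay on the whole organism with Mus musculus as the target; a lower number here means that less compound is needed, a higher number that more compound is needed for the effect:
- compound 1 `NC(=O)/C=C1\CCc2c(F)cccc21`: > 100 mg/kg (a limit)
- compound 2 `O=C(/C=C1\CCc2c1ccc(F)c2F)NC1CC1`: 62 mg/kg
- compound 3 `NC(=O)/C=C1\CCc2cc(F)ccc21`: 56 mg/kg

Compound 1 gives > 100 mg/kg, which is a limit of the assay and not a number.

Compound 3 stands at 56 mg/kg, and compound 2 stands at 62 mg/kg. These two values lie within the scatter of each other, so neither can be ranked ahead of the other. Among the measured compounds shown here, they are the only two numbers.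

The next compound is compound 4 `NC(=O)/C=C1\CCc2c1ccc(F)c2F`. It derives from compound 3 by placing fluoro in place of hydrogen on an aromatic carbon, ortho to a fluoro group (fluoro in place of hydrogen on an aromatic carbon).

For the measured compounds named here, no two measured compounds differ in one place only, so the series offers no direct measure for a step of this kind. The starting point is therefore the value of compound 3, 56 mg/kg. From the compounds shown here alone, with so little to go on, the expectation is no shift beyond the scatter, and the direction remains open. The estimated step of a 1.1-fold lower number from compound 3 to compound 4 (0.05 log units; within the scatter) is expected to stay within that scatter. The series also shows (the limit of > 100 mg/kg in this assay, at which 1 of the 3 values shown sits), so a limit reading remains possible and the expected range is kept wide.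

For compound 4 the estimated value is 50 mg/kg, with an expected range of 25 mg/kg to 100 mg/kg.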

Compound 4, dose for half-maximal effect: 45 mg/kg
Compound 4: the middle estimate sits 1.1-fold (0.05 log units) above what was measured; the measured number falls inside the stated range.
By their numbers in this assay, from the lowest: compounds 4, 3 and 2 (each within the scatter of the next). At a limit, above all of these: compound 1.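

In this assay, fluoro in place of hydrogen on this aromatic carbon, ortho to a fluoro group, gives a 1.2-fold lower number from compound 3 to compound 4 (0.09 log units; within the scatter), so this change on the fluoro-bearing core shows no shift that can be told from the scatter. The same kind of replacement, read from the other singly fluorinated amide, gives an at least 2.2-fold lower number from compound 1 to compound 4 (0.34 log units; beyond the scatter); this is the only new step beyond the scatter, and its starting reading is a limit, so it gives a bound and no exact size: the limit of > 100 mg/kg in this assay, at which 1 of the 4 values shown sits.

With both fluoro groups in place, hydrogen in place of cyclopropyl on the amide-type nitrogen gives a 1.4-fold lower number from compound 2 to compound 4 (0.14 log units; within the scatter), so this pair shows no separation at that nitrogen either.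

From the compounds shown here alone, whether chloro, methoxy or an amine on this aromatic carbon would move the number beyond the scatter stays open. Also open, going by these compounds, is whether a longer chain, such as n-butyl, on the amide-type nitrogen would leave the number within the scatter of the hydrogen and cyclopropyl amides.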